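A Methyl Added to a Saturated Ring Across Two Cores

This account rests on a few compounds, and the source may have more. Where it says the series, first, only, none or still open, it means among the compounds named here.

Compound 1 `COc1cc2c(Oc3ccc(NC(=O)c4nn(-c5ccccc5C)c(=O)cc4C)cc3F)ccnc2cc1OCCCN1CCCCC1` was tested in a functional assay on NCI-H460 cells (Homo sapiens) for inhibition, read by MTT assay, with a stated time of 72 h (on this read-out higher numbers stand for weaker inhibition and lower numbers for stronger inhibition), where compound 1 gives 3220 nM. Compound 2 `COc1cc2c(Oc3ccc(NC(=O)c4nn(-c5ccccc5C)c(=O)cc4C)cc3F)ccnc2cc1OCCCN1CCC(C)CC1` differs from it by methyl in place of hydrogen on a saturated ring carbon, and in this assay compound 2 gives 2260 nM; that step is a 1.4-fold lower number from compound 1 to compound 2 (0.15 log units; within the scatter). Compound 3 `COc1cc2c(Oc3ccc(NC(=O)c4nn(-c5cccc(F)c5)c(=O)cc4C)cc3F)ccnc2cc1OCCCN1CCCCC1` carries a different core, differing from compound 1 by 3-fluorophenyl in place of 2-methylphenyl on an aromatic nitrogen; in this assay compound 3 gives 360 nM, and the step is an 8.9-fold lower number from compound 1 to compound 3 (0.95 log units; beyond the scatter). Compound 4 `COc1cc2c(Oc3ccc(NC(=O)c4nn(-c5cccc(F)c5)c(=O)cc4C)cc3F)ccnc2cc1OCCCN1CCC(C)CC1` applies to compound 3 the same change that turned compound 1 into compound 2, namely (methyl in place of hydrogen on a saturated ring carbon). The step is expected to be a 1.3-fold lower number from compound 3 to compound 4 (0.11 log units; within the scatter) because the earlier step was a 1.4-fold lower number from compound 1 to compound 2 (0.15 log units; within the scatter), which hardly moved the number. Compound 4 is therefore expected to give about 280 nM in this assay, most likely between 120 nM and 650 nM.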

Compound 4, half-maximal inhibitory concentration: 250 nM
Compound 4: middle estimate off by 1.1-fold (0.05 log units), on the high side; the measured number falls inside the stated range.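

In this assay, adding the methyl on the core of compound 3 gives a 1.4-fold lower number from compound 3 to compound 4 (0.16 log units; within the scatter), and this matches the step on the core of compound 1: the same change on two cores in this assay, a 1.4-fold lower number (0.15 log units; within the scatter) from compound 1 to compound 2 and a 1.4-fold lower number (0.16 log units; within the scatter) from compound 3 to compound 4, 1.0-fold (0.00 log units) apart, within the scatter of two such steps. Placing 3-fluorophenyl where 2-methylphenyl stood also gives much the same result with the 4-methylpiperidin-1-yl group present, a 9.0-fold lower number from compound 2 to compound 4 (0.96 log units; beyond the scatter): the same change on two cores in this assay, an 8.9-fold lower number (0.95 log units; beyond the scatter) from compound 1 to compound 3 and a 9.0-fold lower number (0.96 log units; beyond the scatter) from compound 2 to compound 4, 1.0-fold (0.00 log units) apart, within the scatter of two such steps. The two changes therefore combine predictably across these four compounds, but this rests on a single pair of cores in one cell assay, and the methyl step itself stays within the scatter, so it shows no real effect of the methyl.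

On these data alone, whether an ethyl or a hydroxyl group on that ring carbon would behave the same way remains open. So does the outcome of replacing the piperidine with a morpholine.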